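The compounds below may be only part of what the source reports. "The series", "measured", "known", "first", "only" and "open" are said of these compounds alone.

Measured so far:
Compound 1 `Nc1ccccc1NC(=O)CCCCCN(CC(=O)NCc1ccccc1)C(=O)c1cccc2ccccc12` — in an assay on Sf9 cells for inhibition of protein deacetylase HDAC6 (Homo sapiens), read by fluorescence, with a stated time of 90 min (a lower number here means a stronger inhibitor, a higher number a weaker inhibitor), compound 1 gives > 10000 nM, a limit of the assay rather than a number.
Compound 2 `Nc1ccccc1NC(=O)CCCCCN(CC(=O)NC1CCCCC1)C(=O)c1cccc2ccccc12` — compound 2 gives > 10000 nM, likewise a limit.
Compound 3 `Nc1ccccc1NC(=O)CCCCCN(CC(=O)NC1CCCCC1)C(=O)c1ccccc1` — compound 3 gives > 10000 nM, again a limit.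

Compound 1 therefore stands only at a limit in this assay; no number is known for it. The step to compound 4 `CN(C)c1ccc(C(=O)N(CCCCCC(=O)Nc2ccccc2N)CC(=O)NCc2ccccc2)cc1` is 4-(dimethylamino)phenyl in place of naphthalen-1-yl on a carbonyl carbon. Among the compounds with values here, two measured steps touch the same part of the shared core: a step that the two limits leave unreadable from compound 1 to compound 2 and a step that the two limits leave unreadable from compound 2 to compound 3. Both are unreadable because every value shown sits at the limit of > 10000 nM in this assay, at which 3 of the 3 values shown sit. The step from compound 2 to compound 3 is also an exchange of the aryl group on the carbonyl carbon, the closest measured counterpart of the present change, yet its size cannot be read either. Nothing in the set shows a readable movement in this assay. Compound 4 is accordingly expected to stay at or near the limit, estimated at 15000 nM with a range of 3000 nM to 60000 nM. The implied step that the limit leaves unreadable from compound 1 to compound 4 is itself an expectation that cannot be checked against a limit.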

Compound 4, half-maximal inhibitory concentration: > 10000 nM
Compound 4: only a limit was reported (the forecaster's own chance of this, stated with the estimate: 75%); the middle value is on the limit's open side.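

In this assay compound 4 gives > 10000 nM, a limit and not a number. The comparison of compound 1 with compound 4 therefore yields no readable step: the limit of > 10000 nM in this assay, at which 4 of the 4 values shown sit. The compounds shown leave open which change to the shared core, if any, would give a measurable value in this assay.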